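Moving One Hydroxyl Group to a New Ring Position

The source may report more compounds than this note shows. Statements on the series, on what has been measured and on what is new or still open speak of the compounds shown alone.

Of the compounds shown here, two built on a shared core have been tested in a functional assay on HeLa cells (Homo sapiens) for inhibition; a lower number here means a stronger inhibitor, a higher number a weaker inhibitor. Compound 1 `Oc1ccc(-c2cc(-c3ccc(OC(F)(F)F)cc3)cc(-c3ccccc3O)n2)cc1` carries a 4-hydroxyphenyl group and a 2-hydroxyphenyl group. In this assay compound 1 gives > 50000 nM, which is a limit of the assay and not a measured number. Compound 2 `Oc1cccc(-c2cc(-c3ccc(OC(F)(F)F)cc3)cc(-c3cccc(O)c3)n2)c1` carries two 3-hydroxyphenyl groups, and in this assay compound 2 gives 18700 nM. Among the compounds with values here, this is the only measured number in the set, as the other value is a limit, so compound 2 is the only compound whose inhibition has actually been quantified, and that inhibition is weak.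

Compound 3 `Oc1ccc(-c2cc(-c3ccc(OC(F)(F)F)cc3)cc(-c3cccc(O)c3)n2)cc1` has the same atoms as compound 2, joined differently: 4-hydroxyphenyl in place of 3-hydroxyphenyl on an aromatic carbon. Within the data shown here, no two measured compounds differ in a single place, so there is no measured step to lean on. Compound 1, which also carries a 4-hydroxyphenyl group, sits at the limit of > 50000 nM in this assay, at which 1 of the 2 values shown sits. The step from compound 2 to compound 3 is expected to be a loss of potency beyond the usual scatter, about a 1.9-fold higher number from compound 2 to compound 3 (0.27 log units; within the scatter). The estimate for compound 3 is 35000 nM, expected to fall between 12000 nM and 100000 nM.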

Compound 3, half-maximal inhibitory concentration: 27800 nM
For compound 3 the middle estimate is 1.3-fold (0.10 log units) above the measured one; the measured number falls inside the stated range.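

Within the data shown here, this is the first measured step that changes a single place, and in this assay putting 4-hydroxyphenyl in place of 3-hydroxyphenyl on the aromatic carbon next to the ring nitrogen gives a 1.5-fold higher number from compound 2 to compound 3 (0.17 log units; within the scatter), so the two compounds cannot be told apart here and the hydroxyl position on this ring makes no readable difference. Going by these compounds, the second new step concerns the other hydroxyphenyl group, where 3-hydroxyphenyl in place of 2-hydroxyphenyl gives an at least 1.7-fold lower number from compound 1 to compound 3 (0.25 log units; that floor lies within the scatter), so the true size of this step is unknown and the smallest size it could have does not clear the usual scatter. Compound 1 gives a limit of the assay and not a number, so it offers only a floor for that comparison: the limit of > 50000 nM in this assay, at which 1 of the 3 values shown sits.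

All three compounds carry hydroxyphenyl groups on the shared core, so these results say nothing about how a different group would behave at this place. On these data alone, whether an aminophenyl group or a phenyl ring bearing a carboxylic acid would give a number clearly apart from that of compound 3 remains open.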